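From dichlorophenyl to chlorofluorophenyl on a shared core

This account rests on a few compounds, and the source may have more. Where it says the series, first, only, none or still open, it means among the compounds named here.

Compound 3 `C=CC(=O)Nc1cccc(NC(=O)CSc2nc(Nc3ccc(Cl)c(Cl)c3)c3ccccc3n2)c1` is one of three measured compounds built on the same core, differing only in the aryl group carried by the ring nitrogen. In a functional assay on NCI-H1975 cells (Homo sapiens) for inhibition, read by MTT assay, with a stated time of 72 h (a lower number here means a stronger inhibitor, a higher number a weaker inhibitor), compound 3 gives 19100 nM, the second highest of the three numbers. Its nearest neighbour is compound 2 `C=CC(=O)Nc1cccc(NC(=O)CSc2nc(Nc3cccc([N+](=O)[O-])c3)c3ccccc3n2)c1`, which gives 22600 nM; the two lie within the scatter, as the step of a 1.2-fold lower number from compound 2 to compound 3 (0.07 log units; within the scatter) shows. Compound 1 `C=CC(=O)Nc1cccc(NC(=O)CSc2nc(Nc3cccc(F)c3)c3ccccc3n2)c1` gives 2030 nM, and the step of a 9.4-fold higher number from compound 1 to compound 3 (0.97 log units; beyond the scatter) is beyond the scatter, as is the step of an 11-fold higher number from compound 1 to compound 2 (1.05 log units; beyond the scatter).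

Compound 4 `C=CC(=O)Nc1cccc(NC(=O)CSc2nc(Nc3ccc(F)c(Cl)c3)c3ccccc3n2)c1` has not yet been measured. It differs from compound 3 by fluoro in place of chloro on an aromatic carbon, on an aromatic carbon of a six-membered aromatic ring of carbon only, ortho to a chloro group and para to a large group. Among the compounds with values here, no measured step exchanges a single chloro for a fluoro; the measured steps swap the whole aryl group, and compound 4 sits between compound 1 and compound 3 in its substitution. The analyst therefore expects a modest step at most, probably toward a lower number, estimated as a 1.6-fold lower number from compound 3 to compound 4 (0.20 log units; within the scatter) in this assay. The estimate for compound 4 in this assay is 12000 nM, with an expected range from 4000 nM to 36000 nM.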

Compound 4, half-maximal inhibitory concentration: > 50000 nM
Compound 4: a limit, no number; the forecaster's own chance of this, stated with the estimate: 5%; middle value at least 4.1-fold (0.61 log units) from the limit.
By their numbers in this assay, from the lowest: compound 1; then compounds 3 and 2 (each within the scatter of the next). At a limit, above all of these: compound 4.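

In this assay compound 4 stands at a limit of the assay and not at a number: the limit of > 50000 nM in this assay, at which 1 of the 4 values shown sits. Fluoro in place of chloro, on the aromatic carbon ortho to a chloro group and para to a large group, gives an at least 2.6-fold higher number from compound 3 to compound 4 (0.41 log units; beyond the scatter), the only step shown that changes one atom at this position, whereas the earlier steps exchanged the whole aryl group and so could not separate this carbon from the rest of the ring. The two further steps, an at least 2.2-fold higher number from compound 2 to compound 4 (0.34 log units; beyond the scatter) and an at least 24-fold higher number from compound 1 to compound 4 (1.39 log units; beyond the scatter), show that a fluoro on the aryl group does not by itself go with the low number of compound 1, as compound 4 also carries one and stands above all three earlier compounds.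

The limit leaves the true size of these steps open, and the compounds shown cannot tell whether the change depends on the chloro group that remains on the ring. As far as these compounds go, how a methyl, a methoxy or an amine would read on that same carbon, with the chloro group kept, also remains open.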